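Methoxy for Methylamino: Compound 4 Expected Inactive

The compounds below may be only part of what the source reports. "The series", "measured", "known", "first", "only" and "open" are said of these compounds alone.

Compound 1 `O=c1[nH]c(=S)ccn1[C@@H]1O[C@H](COP(=O)(O)O)[C@@H](O)[C@H]1O`: > 100000 nM
Compound 2 `CNc1nc(=O)ccn1[C@@H]1O[C@H](COP(=O)(O)O)[C@@H](O)[C@H]1O`: > 100000 nM
Compound 3 `CCCSc1nc(=O)ccn1[C@@H]1O[C@H](COP(=O)(O)OP(=O)(O)O)[C@@H](O)[C@H]1O`: >= 100000 nM

In an in vitro functional assay on 1321-N1 cells for agonist activity at P2Y purinoceptor 6 (Homo sapiens), read by scintillation proximity assay and inositol phosphate accumulation (on this read-out lower numbers stand for an effect already at smaller amounts and higher numbers for an effect only at larger amounts of compound), compound 1 gives > 100000 nM, which is a limit of the assay and not a number. Compound 2 gives > 100000 nM in this assay, again a limit. Compound 3 gives >= 100000 nM in this assay, also a limit. Compound 2 thus stands at a limit, as do the two other values: two sit at the limit of > 100000 nM in this assay, at which 2 of the 3 values shown sit, and one at the limit of >= 100000 nM in this assay, at which 1 of the 3 values shown sits. Among the measured compounds shown here, no step between measured compounds is known.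

Compound 4 `COc1nc(=O)ccn1[C@@H]1O[C@H](COP(=O)(O)O)[C@@H](O)[C@H]1O` differs from compound 2 by methoxy in place of methylamino on an aromatic carbon. With every value shown a limit, no direction can be read, and no step beyond the scatter is expected. Compound 4 is therefore expected at 100000 nM, between 30000 nM and 300000 nM. The expected step of a number no higher from compound 2 to compound 4 (the limit leaves the size open) stays within the scatter.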

Compound 4, half-maximal effective concentration: 9800 nM
Compound 4: the middle estimate sits 10-fold (1.01 log units) above what was measured, and the stated range ends above it.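

In this assay, replacing methylamino with methoxy on an aromatic carbon between two ring nitrogen atoms gives an at least 10-fold lower number from compound 2 to compound 4 (1.00 log units; beyond the scatter). Among the compounds shown here, this is the first sign that a group at this place can bring a measurable effect, and two groups with equal heavy-atom counts give clearly different results here. The step has no fixed size, as compound 2 stands at a limit: the limit of > 100000 nM in this assay, at which 2 of the 4 values shown sit.

The compounds shown leave open whether the step follows from the hydrogen-bond donor that methylamino carries and methoxy lacks, or from the exchange of nitrogen for oxygen. They also leave open how ethoxy, a longer propoxy chain or dimethylamino would behave at this place.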